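A Phenylcarbamoyl Group in Place of Nonyl

A few compounds are considered here, and "the series" means these few. Any claim that something is new, unique, unknown or untested is made for them only; others in the source may bear on it.

In a functional assay on HL-60 cells (Homo sapiens) for cytotoxicity, read by MTT assay, with a stated time of 24 h (on this read-out lower numbers stand for stronger inhibition and higher numbers for weaker inhibition), compound 2 `CCCCCCCCCCn1cc(Cn2nc(N)c3c(C(F)(F)F)cc(-c4ccccc4)nc32)nn1` gives 29.9 ug/mL. Compound 3 `Nc1nn(Cc2cn(-c3ccc(F)c(Cl)c3)nn2)c2nc(-c3ccccc3)cc(C(F)(F)F)c12` gives 35 ug/mL, and compound 1 `Nc1nn(Cc2cn(CCC(F)(F)C(F)(F)C(F)(F)C(F)(F)C(F)(F)C(F)(F)F)nn2)c2nc(-c3ccccc3)cc(C(F)(F)F)c12` gives 97.6 ug/mL, the furthest number from that of compound 2 and beyond the scatter. Compound 4 `Nc1nn(Cc2cn(CC(=O)Nc3ccccc3)nn2)c2nc(-c3ccccc3)cc(C(F)(F)F)c12` has not yet been measured. It carries phenylcarbamoyl in place of nonyl on a saturated chain carbon bound to an aromatic nitrogen. Among the measured compounds shown here, the one measured step bearing on this change is a 1.2-fold higher number from compound 2 to compound 3 (0.07 log units; within the scatter), where 3-chloro-4-fluorophenyl replaces decyl on an aromatic nitrogen. A step beyond the scatter is therefore not expected, and the expected step is a 1.3-fold higher number from compound 2 to compound 4 (0.10 log units; within the scatter). For compound 4 the estimated value is 38 ug/mL, with an expected range from 18 ug/mL to 90 ug/mL.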

Compound 4, half-maximal inhibitory concentration: 96.3 ug/mL
Compound 4: the middle estimate sits 2.5-fold (0.40 log units) below what was measured, outside the stated range (above it).
By their numbers in this assay, from the lowest: compounds 2 and 3 (each within the scatter of the next); then compounds 4 and 1 (each within the scatter of the next).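

Among the compounds shown here, at this position the change does register: in this assay, phenylcarbamoyl in place of nonyl on a saturated chain carbon bound to an aromatic nitrogen gives a 3.2-fold higher number from compound 2 to compound 4 (0.51 log units; beyond the scatter), whereas the only earlier step was within the scatter. (Phenylcarbamoyl)methyl in place of 3-chloro-4-fluorophenyl on an aromatic nitrogen also gives a 2.8-fold higher number from compound 3 to compound 4 (0.44 log units; beyond the scatter), so a six-membered aromatic ring in the substituent does not alone fix the number, since compound 3 and compound 4 both carry one. No measurement shown explains these steps. From the compounds shown here alone, whether an amine or a carboxylic acid on this chain would behave like phenylcarbamoyl remains open.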